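Phenyl to isopropyl at the ring carbon of compound 3

The compounds below may be only part of what the source reports. "The series", "measured", "known", "first", "only" and "open" are said of these compounds alone.

Measured so far in a functional assay on K562 cells (Homo sapiens) for cytotoxicity, read by thymidine incorporation, with a stated time of 48 h, tested at 10 ug/mL; on this read-out lower numbers stand for less inhibition and higher numbers for more inhibition at the one concentration tested (going by the name of the read-out):
compound 1 `O=C1Nc2c(ncn2Cc2ccccc2)C(c2ccccc2)N1Cc1ccccc1`: 90%
compound 2 `O=c1nc2c(ncn2Cc2ccccc2)c(C#Cc2ccccc2)n1Cc1ccccc1`: 100%
compound 3 `O=c1nc2c(ncn2Cc2ccccc2)c(-c2ccccc2)n1Cc1ccccc1`: 70%

Compound 3 stands lowest of the three numbers in this assay; compound 1 sits above it and compound 2 above both, each gap beyond the scatter. For the measured compounds named here, the only step between measured compounds is a number 30 percentage points lower from compound 2 to compound 3 (beyond the scatter), a change at the same aromatic carbon. Compound 4 `CC(C)c1c2ncn(Cc3ccccc3)c2nc(=O)n1Cc1ccccc1` differs from compound 3 by isopropyl in place of phenyl on an aromatic carbon. Going by the values given here, no measured step replaces an aryl group with an alkyl group there, so the direction is not anchored; a modest further decrease in this assay is expected, given that the one change at this carbon went downward, a number 30 percentage points lower from compound 2 to compound 3 (beyond the scatter). The expected step is a number 10 percentage points lower from compound 3 to compound 4 (within the scatter). Compound 4 is estimated at 60%, within 35% to 85%.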

Compound 4, a percentage reported as inhibition, at one concentration (the size of the read-out at that concentration, not a potency): 18%
The estimate for compound 4 lay 42 percentage points above the measured number, outside the stated range (below it).
By their numbers in this assay, from the lowest: compound 4; then compound 3; then compounds 1 and 2 (each within the scatter of the next).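

In this assay, for the compounds shown here, the aromatic carbon next to the ring nitrogen proves far more sensitive than the earlier compounds showed: the change gives a number 52 percentage points lower from compound 3 to compound 4 (beyond the scatter), and against the alkyne it gives a number 82 percentage points lower from compound 2 to compound 4 (beyond the scatter). Among these three compounds, the two substituents carrying a phenyl ring keep much of the inhibition, and isopropyl, with no ring, does not. Nothing available here accounts for this loss.

From the compounds shown here alone, it stays open whether the loss follows the missing ring or isopropyl itself. A cyclohexyl ring, a longer chain ending in phenyl or an amine at this carbon would separate the two.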